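Swapping the Piperidinylmethyl Arm for an Acetyl Group

A few compounds are considered here, and "the series" means these few. Any claim that something is new, unique, unknown or untested is made for them only; others in the source may bear on it.

The series rests on the shared core of compound 1 `CCOC(=O)c1cccc(-c2ccc(O)cc2)c1`, which in an assay on COS-7 cells for inhibition of patatin-like phospholipase domain-containing protein 2 (Mus musculus), tested at 200 uM (on this read-out lower numbers stand for less inhibition and higher numbers for more inhibition at the one concentration tested (going by the name of the read-out)), gives 77%. Compound 2 `CCOC(=O)c1cccc(-c2ccc(CN3CCCCC3)cc2)c1` carries (piperidin-1-yl)methyl in place of hydroxy on an aromatic carbon and in this assay gives 68%; the step of a number 9 percentage points lower from compound 1 to compound 2 (within the scatter) lies within the scatter. For the measured compounds named here, compound 2 stands at the lower end of the two numbers so far, but with compound 1 nearest and the gap within the scatter, the two are not separable. Compound 3 `CCOC(=O)c1cccc(-c2ccc(C(C)=O)cc2)c1` is not yet measured and differs from compound 2 by acetyl in place of (piperidin-1-yl)methyl on an aromatic carbon. Going by the values given here, only one measured step, a number 9 percentage points lower from compound 1 to compound 2 (within the scatter), bears on this change, and it showed that exchanging the group on this aromatic carbon left the read-out within the scatter. A step of a number 2 percentage points higher from compound 2 to compound 3 (within the scatter) is therefore expected, meaning none beyond the scatter. Compound 3 is estimated at 70% in this assay, within a range from 50% to 85%.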

Compound 3, a percentage reported as inhibition, at one concentration (the size of the read-out at that concentration, not a potency): 36%
Estimate against measurement, compound 3: 34 percentage points above; measured number below the stated range.
By their numbers in this assay, from the lowest: compound 3; then compounds 2 and 1 (each within the scatter of the next).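

Acetyl in place of (piperidin-1-yl)methyl on the aromatic carbon para to a large group brings a number 32 percentage points lower from compound 2 to compound 3 (beyond the scatter), and acetyl in place of hydroxy brings a number 41 percentage points lower from compound 1 to compound 3 (beyond the scatter), both in this assay. The position is therefore not indifferent to what it carries: the earlier exchange stayed within the scatter, whereas acetyl sets compound 3 apart from both compound 1 and compound 2. The leaving and entering groups are counted with the same number of hydrogen-bond acceptors, so that count does not separate compound 2 from compound 3.

On these data alone, whether the drop follows the carbonyl or the whole acetyl group stays open, as does how a carboxylic acid, an amine or a longer ketone chain would read here. The single tested concentration also leaves open whether this order would hold as potency. Nothing measured here gives a cause for the drop.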